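This account rests on a few compounds, and the source may have more. Where it says the series, first, only, none or still open, it means among the compounds named here.

Among the measured compounds shown here, in a functional assay on HCT-116 cells (Homo sapiens) (a higher number here means a weaker inhibitor of growth, a lower number a stronger inhibitor of growth), compound 3 `COc1ccc(-c2cc(O)c3c(C)cc(C)nc3n2)cc1` gives 36300 nM, the highest number so far and so the weakest growth inhibition. Compound 2 `COc1ccc(-c2cc(O)c3cccnc3n2)cc1` gives 17800 nM, and compound 1 `Cc1cc(C)c2c(O)cc(-c3ccc(Cl)cc3)nc2n1` gives 14800 nM. Compound 4 `COc1ccc(-c2cc(O)c3ccc(C)nc3n2)cc1` differs from compound 3 in one place, hydrogen in place of methyl on an aromatic carbon, opposite the ring nitrogen. For the measured compounds named here, the only measured single-place step, a 2.5-fold higher number from compound 1 to compound 3 (0.39 log units; beyond the scatter), involves methoxy and chloro instead, so it bears only indirectly and suggests modest changes. Compound 2 has no methyl on the core and shows a lower number than compound 3, so a modest fall is expected. The expected step is a 1.5-fold lower number from compound 3 to compound 4 (0.16 log units; within the scatter). For compound 4, the estimated value is 25000 nM, with an expected range of 13000 nM to 46000 nM.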

Compound 4, concentration for 50% growth inhibition: > 100000 nM
Compound 4 was reported as a limit; the forecaster's own chance of this, stated with the estimate: 10%; middle value at least 4.0-fold (0.60 log units) from the limit.
By their numbers in this assay, from the lowest: compounds 1 and 2 (each within the scatter of the next); then compound 3. At a limit, above all of these: compound 4.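

Compound 4 is reported only as a limit: the limit of > 100000 nM in this assay, at which 1 of the 4 values shown sits. Replacing the methyl opposite the ring nitrogen with hydrogen gives an at least 2.7-fold higher number from compound 3 to compound 4 (0.44 log units; beyond the scatter), so even this small change at this position weakens growth inhibition. Adding one methyl to the core that carries none gives an at least 5.6-fold higher number from compound 2 to compound 4 (0.74 log units; beyond the scatter), so the effect of a methyl here depends on what else the core carries, and methyl groups do not simply add up. As far as these compounds go, whether an amine or a longer chain opposite the ring nitrogen would restore growth inhibition remains open.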